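A few compounds are considered here, and "the series" means these few. Any claim that something is new, unique, unknown or untested is made for them only; others in the source may bear on it.

Measured so far in a functional assay on LoVo cells (Homo sapiens) for cytotoxicity, read by MTT assay, with a stated time of 72 h; on this read-out lower numbers stand for stronger inhibition and higher numbers for weaker inhibition:
compound 1 `O=C(Nc1ccc(-n2ncc3c(Cl)cccc32)cc1)Nc1ccc(Cl)c(C(F)(F)F)c1` gives 3600 nM
compound 2 `O=C(Nc1ccc(-n2ncc3c(Br)cccc32)cc1)Nc1ccc(Cl)c(C(F)(F)F)c1` gives 1700 nM
compound 3 `Cc1cccc2c1cnn2-c1ccc(NC(=O)Nc2ccc(Cl)c(C(F)(F)F)c2)cc1` gives 3900 nM

Compound 3 has the highest number of the three; against compound 1 the step is a 1.1-fold higher number from compound 1 to compound 3 (0.03 log units; within the scatter), within the scatter, while against compound 2 it is a 2.3-fold higher number from compound 2 to compound 3 (0.36 log units; beyond the scatter), beyond it.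

Compound 4 `O=C(Nc1ccc(-n2ncc3cnccc32)cc1)Nc1ccc(Cl)c(C(F)(F)F)c1` differs from compound 3 in this way: a group of 9 heavy atoms (6 carbon, 3 nitrogen; one five-membered aromatic ring with 2 hetero atoms, one six-membered aromatic ring with 1 hetero atom) in place of a group of 10 heavy atoms (8 carbon, 2 nitrogen; one five-membered aromatic ring with 2 hetero atoms, one six-membered aromatic ring of carbon only), on an aromatic carbon. All three measured steps swap one substituent on an aromatic carbon, with the ring kept: the largest is a 2.1-fold lower number from compound 1 to compound 2 (0.33 log units; beyond the scatter). Among the compounds with values here, none exchanges the ring itself, so no measured step bears directly on this change. A move within the scatter is expected, with no clear direction, perhaps a 1.2-fold higher number from compound 3 to compound 4 (0.06 log units; within the scatter). Compound 4 is therefore estimated at 4500 nM, between 1800 nM and 11000 nM.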

Compound 4, half-maximal inhibitory concentration: 8000 nM
Compound 4: the middle estimate sits 1.8-fold (0.25 log units) below what was measured; measured number inside the range.
By their numbers in this assay, from the lowest: compound 2; then compounds 1 and 3 (each within the scatter of the next); then compound 4.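

In this assay, replacing the substituted ring of carbon only with an unsubstituted six-membered aromatic ring with 1 hetero atom weakens inhibition against all three earlier compounds: a 2.1-fold higher number from compound 3 to compound 4 (0.31 log units; beyond the scatter), a 2.2-fold higher number from compound 1 to compound 4 (0.35 log units; beyond the scatter) and a 4.7-fold higher number from compound 2 to compound 4 (0.67 log units; beyond the scatter). Within the data shown here, earlier steps only swapped substituents, so this is the first sign that a ring change here moves the number beyond the scatter. No measured data explain the loss.

Going by these compounds, every step changes both the ring atom and the substituent, so their separate contributions remain open. On these data alone, how a methoxy or amino group on this ring would read also remains open.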